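Swapping thiophene for furan on a nucleoside that does not inhibit

This account rests on a few compounds, and the source may have more. Where it says the series, first, only, none or still open, it means among the compounds named here.

Three nucleoside analogues sharing one fused core were tested in a functional assay on HeLa S3 cells (Homo sapiens) for antiproliferative activity, read by XTT assay, with a stated time of 72 h; a higher number here means a weaker inhibitor, a lower number a stronger inhibitor. Compound 1 `Nc1nc(N)c2c(-c3ccsc3)cn([C@@H]3O[C@H](CO)[C@@H](O)[C@H]3O)c2n1` gives > 20000 nM, which is a limit of the assay rather than a number. Compound 2 `CNc1ncnc2c1c(-c1ccsc1)cn2[C@@H]1O[C@H](CO)[C@@H](O)[C@H]1O` likewise gives > 20000 nM, again a limit and not a measured number. Compound 3 `O=c1[nH]cnc2c1c(-c1cc3ccccc3o1)cn2[C@@H]1O[C@H](CO)[C@@H](O)[C@H]1O` also gives > 20000 nM, once more a limit. Going by the values given here, compound 2 therefore stands exactly where the other two stand, because of the limit of > 20000 nM in this assay, at which 3 of the 3 values shown sit; nothing in the measurements separates any of the three, and no finished step between measured compounds can be drawn from them.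

Compound 4 `CNc1ncnc2c1c(-c1ccoc1)cn2[C@@H]1O[C@H](CO)[C@@H](O)[C@H]1O` has not yet been measured in this assay. It differs from compound 2 in one place: furan-3-yl in place of thiophen-3-yl on an aromatic carbon. The group that leaves and the group that enters each have 5 heavy atoms, one five-membered aromatic ring with 1 hetero atom, 0 hydrogen-bond donors and 1 hydrogen-bond acceptor, and no net charge.

With compound 2 sitting at the limit, the expected outcome for compound 4 in this assay is no step beyond the usual scatter, in either direction. Compound 4 is expected to give 30000 nM, within a range from 10000 nM to 100000 nM. This corresponds to an expected step that the limit leaves unreadable from compound 2 to compound 4.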

Compound 4, half-maximal inhibitory concentration: > 20000 nM
Compound 4 was reported as a limit; the forecaster's own chance of this, stated with the estimate: 85%; the middle value does not contradict the limit.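

In this assay compound 4 gives > 20000 nM, which is a limit and not a number. No step from compound 2 to compound 4 can be read, because both sit at the same limit: the limit of > 20000 nM in this assay, at which 4 of the 4 values shown sit. The compounds shown leave open whether furan-3-yl in place of thiophen-3-yl changes anything on a compound that gives a measurable number.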